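A few compounds are considered here, and "the series" means these few. Any claim that something is new, unique, unknown or untested is made for them only; others in the source may bear on it.

Working notes on the series

All compounds share one core, carrying a five-membered aromatic ring on a saturated chain carbon two bonds along the chain from a carbonyl carbon, and a benzylic amide on the other side. Three have been run in a functional assay for antagonist activity at P2X purinoceptor 7 (Homo sapiens); on this read-out higher numbers stand for weaker inhibition and lower numbers for stronger inhibition. Compound 1 `CC(C)c1n[nH]c(C(C)C)c1CCC(=O)NCc1ccc(F)cc1Cl` gives 126 nM in this assay. Compound 2 `Cc1n[nH]c(C(F)(F)F)c1CCC(=O)NCc1ccc(F)cc1Cl` gives 12.6 nM in this assay. Compound 3 `Cc1cnn(C)c1CCC(=O)NCc1ccc(F)cc1Cl` gives 158 nM in this assay.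

Compound 3 stands at the highest number of the three. Its gap to compound 1 lies within the scatter, so the two cannot be ordered. Its gap to compound 2 lies beyond the scatter, compound 2 sitting at the clearly lower number.

Compound 4 `Cc1noc(C)c1CCC(=O)NCc1ccc(F)cc1Cl` has not yet been measured. Relative to compound 3 the change is 3,5-dimethyl-1,2-oxazol-4-yl in place of 1,4-dimethyl-1H-pyrazol-5-yl on a saturated chain carbon, two bonds along the chain from a carbonyl carbon. Among the compounds with values here, no measured pair in this set shows the effect of swapping one such ring for another with the same count of heavy atoms and acceptors; compound 1 and compound 3 differ in more than one place and sit within the scatter of each other, which is the nearest hint that the ring itself does not dominate the number.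

For compound 4 the step from compound 3 is expected to be small, a 1.3-fold higher number from compound 3 to compound 4 (0.10 log units; within the scatter), with no confident direction and not clearly beyond the scatter. The estimate for compound 4 in this assay is 200 nM, within a range of 70 nM to 600 nM.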

Compound 4, half-maximal inhibitory concentration: 63.1 nM
For compound 4 the middle estimate is 3.2-fold (0.50 log units) above the measured one, and the stated range ends above it.
By their numbers in this assay, from the lowest: compound 2; then compounds 4, 1 and 3 (each within the scatter of the next, the first and the last beyond it).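

In this assay, within the data shown here, 3,5-dimethyl-1,2-oxazol-4-yl in place of 1,4-dimethyl-1H-pyrazol-5-yl on a saturated chain carbon, two bonds along the chain from a carbonyl carbon, gives a 2.5-fold lower number from compound 3 to compound 4 (0.40 log units; beyond the scatter), the first step that changes one place only. The two groups match in heavy atoms, hydrogen-bond donors, hydrogen-bond acceptors and net charge, yet the number still moves beyond the scatter, though modestly, so these counts alone do not fix the number at this position. Nothing available here bears on what lies behind the step.

This single step cannot separate the exchange of a ring nitrogen for oxygen from the different arrangement of the two methyl groups, and it gives no reading on any other pair of rings at this position. Also open, on these data alone, is whether the step would persist with a longer chain carrying the 3,5-dimethyl-1,2-oxazol-4-yl group, and how an amine or a carboxylic acid on that group would shift the number.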